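The source may hold more compounds than are shown below. What is called first, only, known or untested is meant among the compounds shown, and "the series" means these compounds.

Compound 1 `Cc1nc(-c2ccc(C(F)(F)F)cc2)sc1CNc1ccc(C(=O)O)cc1` carries a carboxy group on the aromatic ring and is the weaker of the two compounds for which a number is given here. In a functional assay on CHO cells for agonist activity at Free fatty acid receptor 1 (Homo sapiens), read by a luciferase reporter (on this read-out lower numbers stand for smaller maximal responses and higher numbers for larger maximal responses), compound 1 gives 10%. Compound 3 `NC(=O)CCc1ccc(NCc2cccc(Oc3ccccc3)c2)cc1` sits a long way above it: in this assay compound 3 gives 68%, a gap well beyond the scatter. Compound 2 `O=C(O)[C@H]1C[C@@H]1c1ccc(NCc2cccc(Oc3ccccc3)c2)cc1` has a cyclopropyl acid on a different core and was measured more than once; in this assay compound 2 gives 88%; 72% (2 entries), and the repeated entries the several entries of compound 2 in this assay, 88%; 72% (2 entries) show how far such values can move between runs.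

Compound 4 `Cc1nc(-c2ccc(C(F)(F)F)cc2)sc1CNc1ccc([C@H]2C[C@@H]2C(=O)NO)cc1` keeps the core of compound 1 and differs from it in one place: 2-(hydroxycarbamoyl)cyclopropyl in place of carboxy on an aromatic carbon. For the measured compounds named here, no step between measured compounds matches this change, so there is no direct precedent to read from. The two compounds bearing a cyclopropyl group or an amide on their acid side, compound 2 and compound 3, both reach large maximal responses, but they also differ from compound 1 elsewhere, so their values show only what a cyclopropyl or amide end can be paired with.

Compound 4 is expected to move upward from compound 1 by a number 35 percentage points higher from compound 1 to compound 4 (beyond the scatter), a step beyond the scatter. Compound 4 is therefore estimated to reach 45%, with a range from 15% to 80%.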

Compound 4, largest response reached (reported as percent of maximum), in percent of the reference or control that the assay uses: 78%
Estimate against measurement, compound 4: 33 percentage points below; measured number inside the range.
By their numbers in this assay, from the lowest: compound 1; then compounds 3 and 4 (each within the scatter of the next).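

In this assay, for the compounds shown here, 2-(hydroxycarbamoyl)cyclopropyl in place of carboxy on an aromatic carbon, para to a large group, brings a number 68 percentage points higher from compound 1 to compound 4 (beyond the scatter), and this is the first step that can be read at this position. On the core of compound 1, then, the position accepts the larger group, with its three-membered ring and two defined stereocentres, and a carboxy group directly on the aromatic carbon is not required there for a large maximal response. This single change also moves the read-out further than repeated measurements of one compound differ from each other, as seen in the spread of: the several entries of compound 2 in this assay, 88%; 72% (2 entries).

The change brings in the three-membered ring and the hydroxycarbamoyl end together, so the compounds shown do not tell which of the two carries the step; a cyclopropane carboxylic acid or a cyclopropane primary amide on the core of compound 1 would separate them. They also leave open what the opposite configuration at the two stereocentres, or an open propanoic acid chain in place of the ring, would give at this position.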